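Benzoyl in place of cyclopropylcarbonyl: expected cytotoxicity

The compounds below may be only part of what the source reports. "The series", "measured", "known", "first", "only" and "open" are said of these compounds alone.

Two compounds on the shared core have been run in a functional assay on A549 cells (Homo sapiens) for cytotoxicity, read by MTT assay, with a stated time of 48 h; a higher number here means a weaker inhibitor, a lower number a stronger inhibitor. Compound 1 `COc1cc(-c2nnc3n2NC(c2ccco2)C(C(=O)c2ccc(Cl)cc2)S3)cc(OC)c1OC` carries a 4-chlorophenyl on the carbonyl carbon; in this assay compound 1 gives 51400 nM. Compound 2 `COc1cc(-c2nnc3n2NC(c2ccco2)C(C(=O)C2CC2)S3)cc(OC)c1OC` carries a cyclopropyl in that place. In this assay compound 2 reaches only the limit of the assay, > 100000 nM, so no number is known for it, and on the numbers shown it stands at the weak end, at the limit of > 100000 nM in this assay, at which 1 of the 2 values shown sits. Going by the values given here, the one measured step, an at least 1.9-fold higher number from compound 1 to compound 2 (0.28 log units; that floor lies within the scatter), sits at a floor that lies within the scatter.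

Compound 3 `COc1cc(-c2nnc3n2NC(c2ccco2)C(C(=O)c2ccccc2)S3)cc(OC)c1OC` differs from compound 2 by phenyl in place of cyclopropyl on a carbonyl carbon. This change partly reverses the measured step of an at least 1.9-fold higher number from compound 1 to compound 2 (0.28 log units; that floor lies within the scatter), since a phenyl ketone returns where compound 1 had a 4-chlorophenyl ketone. Among the compounds with values here, only that step bears on it, and it was small; a step back of about that size toward the number of compound 1 is therefore expected, though compound 3 may also stay at the limit. For compound 3 a value of 80000 nM is expected, between 35000 nM and 200000 nM, which means an expected step of an at least 1.2-fold lower number from compound 2 to compound 3 (0.09 log units; that floor lies within the scatter).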

Compound 3, half-maximal inhibitory concentration: 33400 nM
Compound 3: middle estimate off by 2.4-fold (0.38 log units), on the high side; measured number outside the range, below it.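

Phenyl in place of cyclopropyl on a carbonyl carbon gives an at least 2.9-fold lower number from compound 2 to compound 3 (0.47 log units; beyond the scatter) in this assay, so the group on this carbonyl carbon can shift the read-out by more than the scatter, which the earlier step could not show. Hydrogen in place of chloro on an aromatic carbon gives a 1.5-fold lower number from compound 1 to compound 3 (0.19 log units; within the scatter), so compound 1 and compound 3 cannot be ordered, and the chloro is not required for the step seen with the phenyl. Compound 2 stands only as a limit of the assay, so the full size of the step to the phenyl ketone stays unknown and only its floor can be read: the limit of > 100000 nM in this assay, at which 1 of the 3 values shown sits.

As far as these compounds go, what a methoxy group or an amine on an aromatic carbon of the benzoyl group would do in place of the chloro stays open, since hydrogen and chloro alone give no trend across substituents. From the compounds shown here alone, whether a longer alkyl chain on the carbonyl carbon behaves like cyclopropyl or like phenyl also stays open, so the step cannot yet be tied to the aromatic ring as such rather than to the size of the group.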